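A few compounds are considered here, and "the series" means these few. Any claim that something is new, unique, unknown or untested is made for them only; others in the source may bear on it.

Working notes on the ester series.

Among the compounds with values here, compound 2, `CC1=CC[C@H](C(C)C)c2cc(C)c(OC(=O)c3cccc([N+](=O)[O-])c3)cc21`, gives 45.9% in a functional assay on HCT-15 cells (Homo sapiens) for antiproliferative activity, read by sulforhodamine B assay, with a stated time of 48 h, tested at 50 uM (a higher number here means more inhibition at the concentration tested (going by the name of the read-out), a lower number less inhibition), which is the highest of the two numbers available; compound 1, `CC1=CC[C@H](C(C)C)c2cc(C)c(OC(=O)c3cccc(Cl)c3)cc21`, gives 5.3% in this assay, and the single step on record, a number 40.6 percentage points higher from compound 1 to compound 2 (beyond the scatter), is the nitro in place of chloro on an aromatic carbon.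

Compound 3, `COc1ccc(C(=O)Oc2cc3c(cc2C)[C@@H](C(C)C)CC=C3C)cc1`, differs from compound 2 as follows: 4-methoxyphenyl in place of 3-nitrophenyl on a carbonyl carbon. Within the data shown here, no measured step covers a 4-methoxyphenyl, so the only step bearing on this change is a number 40.6 percentage points higher from compound 1 to compound 2 (beyond the scatter), which shows that exchanging the group on the aryl of the ester moves the read-out in this assay by a large amount. Since the 3-nitrophenyl, whose arrival gave that large rise, now leaves, the expectation for compound 3 is a drop back toward the level of compound 1, though the size is uncertain because only 5.3% offers a second anchor.

For compound 3 the expected step is a number 30.9 percentage points lower from compound 2 to compound 3 (beyond the scatter) in this assay. The estimate for compound 3 is therefore 15%, within a range from 0% to 45%.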

Compound 3, a percentage reported as inhibition, at one concentration (the size of the read-out at that concentration, not a potency): 30.8%
Estimate against measurement, compound 3: 15.8 percentage points below; low and high end bracket the measured number.
By their numbers in this assay, from the lowest: compound 1; then compound 3; then compound 2.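

At the carbonyl carbon of the ester, the 4-methoxyphenyl gives an intermediate read-out in this assay: a number 15.1 percentage points lower from compound 2 to compound 3 (beyond the scatter), while a number 25.5 percentage points higher from compound 1 to compound 3 (beyond the scatter). Within the data shown here, the 3-nitrophenyl is therefore not the only aryl group at this position to stand clear of the 3-chlorophenyl ester, and with three compounds the read-out falls on three separate levels rather than two, with the 4-methoxyphenyl, which carries no nitrogen, taking the middle one. No measurement on hand bears on what lies behind these differences.

The 3-nitrophenyl and 4-methoxyphenyl differ both in the substituent and in its numbered place on the aryl ring, as do the 3-chlorophenyl and 4-methoxyphenyl, so the compounds shown do not separate these two changes. Also open, on these data alone, is how an amine or a carboxylic acid on the aryl ring, or a longer alkyl chain in place of the aryl group on the carbonyl carbon, would read in this assay, and whether the same order would hold at concentrations other than the single one tested.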